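Fluoro in Place of Nitro: Compound 3 to Compound 4

The compounds below may be only part of what the source reports. "The series", "measured", "known", "first", "only" and "open" are said of these compounds alone.

Compound 3 `Cn1c(/C=C2/C(=O)Nc3ccc([N+](=O)[O-])cc32)nc2ccccc21` was tested in a functional assay on PC-3 cells (Homo sapiens) for cytotoxicity, read by MTT assay, with a stated time of 48 h (on this read-out higher numbers stand for weaker inhibition and lower numbers for stronger inhibition), where compound 3 gives only a limit, > 50000 nM. Two of the three values shown sit at this point, (the limit of > 50000 nM in this assay, at which 2 of the 3 values shown sit). Compound 1 `CCn1c(/C=C2/C(=O)Nc3ccc(F)cc32)nc2ccccc21` also stands at a limit in this assay, giving > 50000 nM. Compound 2 `CC(C)n1c(/C=C2/C(=O)Nc3ccc(F)cc32)nc2ccccc21` gives 20800 nM in this assay. Within the data shown here, the one measured step, an at least 2.4-fold lower number from compound 1 to compound 2 (0.38 log units; beyond the scatter), concerns a different part of the shared core and does not bear on the change now in question. Compound 4 `Cn1c(/C=C2/C(=O)Nc3ccc(F)cc32)nc2ccccc21` differs from compound 3 by fluoro in place of nitro on an aromatic carbon. Among the measured compounds shown here, no measured step addresses this change; the limit of compound 3, > 50000 nM, is the only guide. Compound 4 is therefore expected to stay weak, with an estimated a number no higher from compound 3 to compound 4 (the limit leaves the size open) of no size beyond the scatter, giving 50000 nM (range 20000 nM to 150000 nM).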

Compound 4, half-maximal inhibitory concentration: 34300 nM
Estimate against measurement, compound 4: 1.5-fold (0.16 log units) above; measured number inside the range.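

With fluoro on this aromatic carbon, compound 4 gives a measured number in this assay where nitro in compound 3 gave only a limit. Fluoro in place of nitro on an aromatic carbon gives an at least 1.4-fold lower number from compound 3 to compound 4 (0.16 log units; that floor lies within the scatter), and hydrogen in place of methyl on a saturated chain carbon bound to an aromatic nitrogen gives an at least 1.4-fold lower number from compound 1 to compound 4 (0.16 log units; that floor lies within the scatter), so each of these two steps has only a floor, which lies within the scatter: the limit of > 50000 nM in this assay, at which 2 of the 4 values shown sit. Methyl in place of isopropyl on an aromatic nitrogen gives a 1.6-fold higher number from compound 2 to compound 4 (0.22 log units; within the scatter), so these two groups do not separate in this assay. The compounds shown leave open whether an amine or a carboxylic acid on this aromatic carbon, or a longer chain on the aromatic nitrogen, would give a clearly lower number.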